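This account rests on a few compounds, and the source may have more. Where it says the series, first, only, none or still open, it means among the compounds named here.

Measured so far in an ADME assay on HeLa cells (Homo sapiens) for cytotoxicity, read by ATP content, with a stated time of 3 days; on this read-out higher numbers stand for lower toxicity in this test and lower numbers for higher toxicity in this test:
compound 1 `COc1ccc(-n2c(=O)n(Cc3cc4cc(Cl)ccc4n3CCCC#N)c3cnccc32)c(F)c1` gives > 50000 nM;
compound 2 `O=c1n(Cc2cc3ccncc3n2CCCCO)c2cnccc2n1C1CC1` gives > 100000 nM;
compound 3 `O=c1n(Cc2nc3cnccc3n2CCCCO)c2cnccc2n1C1CC1` gives > 100000 nM.

Every value here is a limit, not a number. For compound 1 the reading is a limit of this assay, (the limit of > 50000 nM in this assay, at which 1 of the 3 values shown sits). For compound 2 and compound 3 the readings are also limits, (the limit of > 100000 nM in this assay, at which 2 of the 3 values shown sit). So compound 1 stands where all three stand: with no measurable cytotoxicity within the tested range, and no pair of measured compounds differs in one place, so no measured step exists to lean on.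

Compound 4 `N#CCCCn1c(Cn2c(=O)n(-c3ccncc3F)c3ccncc32)cc2cc(Cl)ccc21` has not yet been measured. It differs from compound 1 by 3-fluoropyridin-4-yl in place of 2-fluoro-4-methoxyphenyl on an aromatic nitrogen. With every measured value at a limit, the expected step in this assay is none beyond the scatter, and compound 4 is expected to sit at a limit as well. The expected step from compound 1 to compound 4 is a number no higher from compound 1 to compound 4 (the limit leaves the size open). For compound 4 the estimated value in this assay is 50000 nM, with a range from 20000 nM to 150000 nM.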

Compound 4, half-maximal cytotoxic concentration: > 50000 nM
Compound 4: no number, only a limit; the forecaster's own chance of this, stated with the estimate: 80%; the middle value lies on the limit itself.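

In this assay compound 4 gives > 50000 nM as a limit and not a number. Compound 1 also stands at a limit, so no step can be read from compound 1 to compound 4. The compounds shown leave open whether swapping 2-fluoro-4-methoxyphenyl for 3-fluoropyridin-4-yl changes the read-out at all, and at what concentration, if any, cytotoxicity would appear.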